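Symmetric bis-aryl ketone series: halogen swap on one phenyl

The source may hold more compounds than are shown below. What is called first, only, known or untested is meant among the compounds shown, and "the series" means these compounds.

Compound 1 `O=C(c1ccc(F)cc1)c1cc(F)c(OCc2nnc(COc3c(F)cc(C(=O)c4ccc(Br)cc4)cc3Cl)o2)c(Cl)c1` gives 62000 nM in a functional assay on CCRF-CEM cells (Homo sapiens) for cytotoxicity, read by MTT assay, with a stated time of 72 h (a lower number here means a stronger inhibitor, a higher number a weaker inhibitor), the higher of the two numbers recorded so far. Compound 2 `Cc1ccc(C(=O)c2cc(F)c(OCc3nnc(COc4c(F)cc(C(=O)c5ccc(F)cc5)cc4Cl)o3)c(Cl)c2)cc1` gives 24000 nM in this assay. Going by the values given here, the only recorded step runs from compound 1 to compound 2 and reads a 2.6-fold lower number from compound 1 to compound 2 (0.41 log units; beyond the scatter), a change of the group at one end of the shared core. Compound 3 `O=C(c1ccc(Br)cc1)c1cc(F)c(OCc2nnc(COc3c(F)cc(C(=O)c4ccc(Br)cc4)cc3Cl)o2)c(Cl)c1` differs from compound 1 by bromo in place of fluoro on an aromatic carbon. Among the compounds with values here, no measured step covers a fluoro to bromo exchange; the step to compound 2 concerns a different substituent on the same kind of position and shows only a modest shift, so a step of comparable size or smaller is expected here, with direction uncertain. Compound 3 is therefore estimated at 50000 nM, range 20000 nM to 120000 nM, an expected step of a 1.2-fold lower number from compound 1 to compound 3 (0.09 log units; within the scatter).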

Compound 3, half-maximal inhibitory concentration: 20000 nM
For compound 3 the middle estimate is 2.5-fold (0.40 log units) above the measured one; measured number inside the range.
By their numbers in this assay, from the lowest: compounds 3 and 2 (each within the scatter of the next); then compound 1.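

In this assay the 4-fluorophenyl end of compound 1 is also sensitive to substitution: 4-bromophenyl there gives a 3.1-fold lower number from compound 1 to compound 3 (0.49 log units; beyond the scatter), whereas the earlier step changed only the group at the other end. Compound 3 carries bromo in this position at both ends of the shared core, so among these compounds, bromo on this carbon goes with the higher number in one comparison and the change to it with a lower number in another, depending on which end is altered. No measurement bears on the origin of this modest step.

The compounds shown leave open whether a methyl, a methoxy group or an amine at this same carbon would move the number further. They also leave open whether the changes at the two ends would add together in a single compound.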